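The source may report more compounds than this note shows. Statements on the series, on what has been measured and on what is new or still open speak of the compounds shown alone.

Values in an ADME assay on RAW264.7 cells (Mus musculus) for cytotoxicity, read by MTT assay; on this read-out higher numbers stand for weaker inhibition and lower numbers for stronger inhibition:
Compound 1 `CCCCCCOc1cccc(O)c1C(=O)/C=C/c1ccc(O)cc1`: > 30000 nM, a limit.
Compound 2 `CCCCCCCCCCOc1cccc(O)c1C(=O)/C=C/c1ccc(O)cc1`: > 30000 nM, a limit.
Compound 3 `CCCCCCCCCCCCCCOc1cccc(O)c1C(=O)/C=C/c1ccc(O)cc1`: > 30000 nM, a limit.

Compound 1 is known only as a limit, > 30000 nM, so no number is available to step from. The whole measured set sits in the same place: the limit of > 30000 nM in this assay, at which 3 of the 3 values shown sit.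

The next structure is compound 4 `CCCCCCOc1cccc(O)c1C(=O)/C=C/c1ccc(OCCCCC)cc1`, and its change from compound 1 is pentyl in place of hydrogen on an oxygen on an aromatic ring. This turns hydroxy to pentyloxy.

The nearest measured changes extend a saturated chain and leave this oxygen untouched: a step that the two limits leave unreadable from compound 1 to compound 2, a step that the two limits leave unreadable from compound 1 to compound 3 and a step that the two limits leave unreadable from compound 2 to compound 3. Among the measured compounds shown here, none of them gives a readable size, and no measured step covers a change at the hydroxy group. No step beyond the scatter is therefore expected in this assay, and a further limit is the likeliest report. The expected step is a step that the limit leaves unreadable from compound 1 to compound 4. For compound 4 the estimate is 35000 nM, with an expected range of 15000 nM to 80000 nM.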

Compound 4, half-maximal inhibitory concentration: > 30000 nM
Compound 4: no number, only a limit; the forecaster's own chance of this, stated with the estimate: 80%; the middle value lies beyond the limit too.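

Among the compounds shown here, compound 1 and compound 4 are both known only as limits in this assay, so no step between them can be read. The compounds shown leave open whether hydroxy to pentyloxy or a longer chain alters the value at all, as all share one result: the limit of > 30000 nM in this assay, at which 4 of the 4 values shown sit.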